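Halogenated aryl hydrazone urea and its expected cytotoxicity

The compounds below may be only part of what the source reports. "The series", "measured", "known", "first", "only" and "open" are said of these compounds alone.

Four compounds share one core. Compound 1 `COc1ccc(OC)c(/C=N/NC(=O)Nc2ccc(Oc3ccnc(-c4nncn4CCN(C)C)c3)c(F)c2)c1` was run in an ADME assay on WI-38 cells (Homo sapiens) for cytotoxicity, read by MTT assay, with a stated time of 72 h (a lower number here means a stronger inhibitor, a higher number a weaker inhibitor), where compound 1 gives "not determined" (no result reported), and compound 3 `CN(C)CCn1cnnc1-c1cc(Oc2ccc(NC(=O)N/N=C/c3cccc(O)c3)cc2F)ccn1` was run there too, where compound 3 gives "not determined" (no result reported); neither returned a number, so no result is reported for either. Among the compounds with values here, the one measured point is compound 2 `CN(C)CCn1cnnc1-c1cc(Oc2ccc(NC(=O)N/N=C/c3cccc(Br)c3)cc2F)ccn1`, which in this assay gives 4230 nM. Compound 3 therefore stands without a number, and the other entry without a number, compound 1, gives it no anchor either; where it lies on this scale is not known.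

The unmeasured compound 4 `CN(C)CCn1cnnc1-c1cc(Oc2ccc(NC(=O)N/N=C/c3ccc(F)cc3Cl)cc2F)ccn1` differs from compound 3 in a single place: 2-chloro-4-fluorophenyl in place of 3-hydroxyphenyl on a carbon with a double bond to nitrogen. Within the data shown here, no step between measured compounds is recorded, so the size of this change in this assay cannot be read from a measured pair. With compound 3 itself lacking a number, the expectation for compound 4 rests on compound 2 alone, whose value of 4230 nM is the only measured point. A result of the same general size, neither clearly stronger nor clearly weaker beyond the scatter, is expected for the new aryl group.

Compound 4 is therefore estimated to give 4500 nM in this assay, with a range of 1500 nM to 15000 nM.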

Compound 4, half-maximal inhibitory concentration: 2090 nM
For compound 4 the middle estimate is 2.2-fold (0.33 log units) above the measured one, within the range that was stated.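

Within the data shown here, the result gives a 2.0-fold lower number from compound 2 to compound 4 (0.31 log units; beyond the scatter), the first measured pair in this assay. It shows that, with the rest of the structure unchanged, replacing 3-bromophenyl with 2-chloro-4-fluorophenyl on a carbon with a double bond to nitrogen moves the read-out by a modest amount beyond the usual scatter, which no single measured point could show. No supporting measurement bears on why the number moves in this pair.

Any step involving compound 1 or compound 3 cannot be read, since neither has a number, so the effect of replacing 3-hydroxyphenyl with 2-chloro-4-fluorophenyl remains unknown. The compounds shown also leave open how a single chlorine or a single fluorine on the phenyl ring would compare with the pair of halogens in compound 4, and whether a non-aromatic group at this place, such as an amine or a carboxylic acid, would give a number of similar size in this assay.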